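Notes on the step from compound 3 to compound 4

A few compounds are considered here, and "the series" means these few. Any claim that something is new, unique, unknown or untested is made for them only; others in the source may bear on it.

In a functional assay on HCT-15 cells (Homo sapiens) for antiproliferative activity, with a stated time of 48 h (on this read-out lower numbers stand for stronger inhibition and higher numbers for weaker inhibition), compound 3 `Cc1cc(=O)c2c(O)cc(OC[C@@H]3CO3)cc2o1` gives 17500 nM, within the scatter of compound 1 `Cc1cc(=O)c2c(OCC3CO3)cc(OCC3CO3)cc2o1` at 12100 nM and far lower than compound 2 `Cc1cc(=O)c2c(OC[C@H]3CO3)cc(OC[C@H]3CO3)cc2o1` at 229000 nM. Compound 4 `Cc1cc(=O)c2c(OC[C@@H]3CO3)cc(OC[C@@H]3CO3)cc2o1` differs from compound 3 by (oxiran-2-yl)methyl in place of hydrogen on an oxygen on an aromatic ring. Among the compounds with values here, no measured step isolates this change. Within the data shown here, the one step that bears on it, a 19-fold higher number from compound 1 to compound 2 (1.28 log units; beyond the scatter), is large and goes with the fact that one of compounds 1 and 2 is drawn with a defined configuration and the other without, at the place where they differ. Compound 4 is drawn with a configuration unlike that of compound 2, so its number is expected near that of compound 1 at 12100 nM, with no step beyond the scatter in this assay. The estimated change is a 1.8-fold lower number from compound 3 to compound 4 (0.24 log units; within the scatter), slightly towards stronger inhibition. For compound 4 the expected value is 10000 nM, with an estimated range of 3000 nM to 40000 nM.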

Compound 4, half-maximal inhibitory concentration: 39500 nM
Estimate against measurement, compound 4: 4.0-fold (0.60 log units) below; the range from low to high includes it.
By their numbers in this assay, from the lowest: compounds 1 and 3 (each within the scatter of the next); then compound 4; then compound 2.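

On the oxygen on an aromatic ring, (oxiran-2-yl)methyl in place of hydrogen brings no gain, with a 2.3-fold higher number from compound 3 to compound 4 (0.35 log units; beyond the scatter). The two mirror-image forms also separate clearly, with a 5.8-fold lower number from compound 2 to compound 4 (0.76 log units; beyond the scatter), so configuration alone shifts the number here: the fact that compounds 2 and 4 differ only in the configuration as drawn. The form drawn without configuration keeps the lower number, with a 3.3-fold higher number from compound 1 to compound 4 (0.51 log units; beyond the scatter): the fact that one of compounds 1 and 4 is drawn with a defined configuration and the other without, at the place where they differ.

The compounds shown leave open whether the oxirane ring itself matters at this oxygen, since none carries an open-chain group such as 2,3-dihydroxypropyl or propyl there. They also leave open how a methyl ether on this oxygen would compare.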